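Trimming the side chain of compound 2

This account rests on a few compounds, and the source may have more. Where it says the series, first, only, none or still open, it means among the compounds named here.

Compound 1 `Cc1c(O)cc(CCCCC(C)C)oc1=O`: > 200000 nM (a limit)
Compound 2 `CC(=O)C(C)CCCCc1cc(O)c(C)c(=O)o1`: > 200000 nM (a limit)

In a functional assay on BGC-823 cells (Homo sapiens) for cytotoxicity, read by MTT assay (on this read-out higher numbers stand for weaker inhibition and lower numbers for stronger inhibition), compound 2 gives > 200000 nM and that is a limit, not a number. Compound 1 gives > 200000 nM as a limit too. Going by the values given here, compound 3 `Cc1c(O)cc(CCCC(C)C)oc1=O` keeps the shared core but carries isopropyl in place of 2-acetylpropyl on a saturated chain carbon, three bonds along the chain from an aromatic carbon as its one change. Among the compounds with values here, the only measured step that the two limits leave unreadable from compound 1 to compound 2 has no readable size and shows no direction, and the evidence is simply the limit of > 200000 nM in this assay, at which 2 of the 2 values shown sit, with no exact number behind it. No step beyond the scatter is therefore expected in this assay in either direction. The expected step of a number no higher from compound 2 to compound 3 (the limit leaves the size open) is a rough estimate. Compound 3 is estimated at 200000 nM with an expected range of 80000 nM to 500000 nM and may well report only a limit.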

Compound 3, half-maximal inhibitory concentration: > 200000 nM
Compound 3: a limit, no number; the forecaster's own chance of this, stated with the estimate: 80%; the middle value lies on the limit itself.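

In this assay compound 3 gives > 200000 nM, a limit and not a number. Going by these compounds alone, no step among compound 1, compound 2 and compound 3 can be read. Going by these compounds, whether these side chain changes alter activity at all stays open.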